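Chain extension in a fluorinated alcohol series

The source may hold more compounds than are shown below. What is called first, only, known or untested is meant among the compounds shown, and "the series" means these compounds.

Measured compounds:
Compound 1 `CC(F)(F)CCCO`: 0.71
Compound 2 `OCCC(F)(F)CF`: 0.27
Compound 3 `CCC(F)(F)CCO`: 0.92

In a physicochemical assay for lipophilicity, read by NMR (on this read-out higher numbers stand for higher lipophilicity and lower numbers for lower lipophilicity), compound 2 stands lowest of the three; compound 1 sits above it and compound 3 higher still. Compound 4 `OCCCC(F)(F)CF` is not yet measured. Its difference from compound 2 is hydroxymethyl in place of hydroxy on a saturated chain carbon, three bonds along the chain from two fluorine atoms. Within the data shown here, no measured pair shows this exact change. The nearest guide is a number 0.65 log units higher from compound 2 to compound 3 (beyond the scatter), a different change on the same chain, which shows how much this read-out moves when one heavy atom is exchanged for another on this scaffold. A one-carbon lengthening is expected to give a modest rise in this assay, estimated as a number 0.45 log units higher from compound 2 to compound 4 (beyond the scatter). Compound 4 is therefore expected near 0.72, within 0.45 to 1.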

Compound 4, partition coefficient: 0.58
Compound 4: middle estimate off by 0.14 log units, on the high side, and the stated range covers the measured number.
By their numbers in this assay, from the lowest: compound 2; then compounds 4, 1 and 3 (each within the scatter of the next, the first and the last beyond it).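

Working notes: in this assay, hydroxymethyl in place of hydroxy on a saturated chain carbon, three bonds along the chain from two fluorine atoms, gives a number 0.31 log units higher from compound 2 to compound 4 (beyond the scatter), the first reading for this change at this position. Fluoro in place of hydrogen on a saturated chain carbon, two bonds along the chain from two fluorine atoms, gives a number 0.13 log units lower from compound 1 to compound 4 (within the scatter), so this exchange is not resolved on this read-out.

On these data alone, whether either step holds with a longer chain, or with an amine in place of the hydroxy, remains open. No supporting data bear on the reason for either step.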